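Fluoro on the pendant phenyl of the chromanone series

The source may hold more compounds than are shown below. What is called first, only, known or untested is meant among the compounds shown, and "the series" means these compounds.

Working notes. In an in vitro assay on BTI-TN-5B1-4 cells for inhibition of Amine oxidase [flavin-containing] B (Homo sapiens) (on this read-out lower numbers stand for stronger inhibition and higher numbers for weaker inhibition), compound 3 `Cc1ccc2c(c1)OC(c1ccccc1)CC2=O` gives 3620 nM, the highest number among the three compounds measured. Compound 2 `COc1ccc(C2CC(=O)c3ccc(C)cc3O2)cc1` gives 3350 nM in this assay; the two values lie within the scatter, so no order between them is claimed. Compound 1 `Cc1ccc(C2CC(=O)c3ccc(C)cc3O2)cc1` gives 500 nM, the lowest number of the set.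

Compound 4 `Cc1ccc2c(c1)OC(c1ccc(F)cc1)CC2=O` is unmeasured. It differs from compound 3 by fluoro in place of hydrogen on an aromatic carbon, placed on an aromatic carbon of a six-membered aromatic ring of carbon only, para to a large group.

Among the compounds with values here, two measured steps bear on this position. The step of a 7.2-fold higher number from compound 1 to compound 3 (0.86 log units; beyond the scatter) shows that a methyl here matters. The step of a 1.1-fold higher number from compound 2 to compound 3 (0.03 log units; within the scatter) shows that a methoxy here does not. Fluoro is a single heavy atom; the two precedents point in different directions, so a modest gain at most is expected for compound 4, of size a 1.6-fold lower number from compound 3 to compound 4 (0.22 log units; within the scatter).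

Estimated value for compound 4 in this assay: 2200 nM, with a range from 700 nM to 6000 nM.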

Compound 4, half-maximal inhibitory concentration: 130 nM
Estimate against measurement, compound 4: 17-fold (1.23 log units) above; the measured number lies below the stated range.
By their numbers in this assay, from the lowest: compound 4; then compound 1; then compounds 2 and 3 (each within the scatter of the next).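

In this assay, fluoro in place of hydrogen on this aromatic carbon, para to a large group, gives the largest step seen at this position (a 28-fold lower number from compound 3 to compound 4 (1.44 log units; beyond the scatter)). Fluoro also outdoes both earlier groups here, with a 26-fold lower number from compound 2 to compound 4 (1.41 log units; beyond the scatter) against methoxy and a 3.8-fold lower number from compound 1 to compound 4 (0.59 log units; beyond the scatter) against methyl, so methyl no longer marks the best result at this position. The order by number is now fluoro, then methyl, then methoxy and hydrogen, with no order between those last two. No measurement shown accounts for this order.

Chloro, trifluoromethyl, nitrile or an amine at the same carbon would show whether the low number is particular to fluoro. As far as these compounds go, whether fluoro on another carbon of this ring gives a similar step also remains open.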